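Dihydroxybenzyl for pyrrolylmethyl on a fluoroquinolone-type core

This account rests on a few compounds, and the source may have more. Where it says the series, first, only, none or still open, it means among the compounds named here.

Compound 1, `Cc1cc(-c2c(F)cc3c(=O)c(Cc4ccc[nH]4)cn(C4CC4)c3c2F)cc(C)n1`, was tested in a functional assay on P388 cells (Mus musculus) for cytotoxicity (on this read-out higher numbers stand for weaker inhibition and lower numbers for stronger inhibition), where it gives 930 nM. Among the three compounds measured, compound 1 stands second highest; its nearest neighbour is compound 3, `Cc1cc(-c2c(F)cc3c(=O)c(Cc4cccc(O)c4O)cn(C4CC4)c3c2F)cc(C)n1`, which gives 880 nM, a difference within the scatter, while compound 2, `Cc1cc(-c2c(F)cc3c(=O)c(Cc4ccccc4)cn(C4CC4)c3c2F)cc(C)n1`, which gives 7300 nM, sits furthest away. The step from compound 1 to compound 2 is a 7.8-fold higher number from compound 1 to compound 2 (0.89 log units; beyond the scatter), the step from compound 2 to compound 3 is an 8.3-fold lower number from compound 2 to compound 3 (0.92 log units; beyond the scatter), and the step from compound 1 to compound 3 is a 1.1-fold lower number from compound 1 to compound 3 (0.02 log units; within the scatter).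

Compound 4, `Cc1cc(-c2c(F)cc3c(=O)c(Cc4cc(O)ccc4O)cn(C4CC4)c3c2F)cc(C)n1`, has not yet been measured in this assay. It differs from compound 1 as follows: 2,5-dihydroxyphenyl in place of 1H-pyrrol-2-yl on a saturated chain carbon bound to an aromatic carbon. Among the measured compounds shown here, the most relevant comparison is the step from compound 1 to compound 3, where a 2,3-dihydroxyphenyl group in the same place left the number unchanged within the scatter; the phenyl of compound 2 is the only change that moved the number beyond the scatter, and a dihydroxyphenyl group reversed that. On this basis the step for compound 4 is expected to be small, a 1.1-fold higher number from compound 1 to compound 4 (0.03 log units; within the scatter), with no change beyond the scatter in either direction. Compound 4 is therefore estimated at 1000 nM, with a range from 400 nM to 2800 nM.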

Compound 4, half-maximal inhibitory concentration: 360 nM
For compound 4 the middle estimate is 2.8-fold (0.44 log units) above the measured one, outside the stated range (below it).
By their numbers in this assay, from the lowest: compound 4; then compounds 3 and 1 (each within the scatter of the next); then compound 2.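

In this assay, the two dihydroxyphenyl groups turn out not to be interchangeable on this saturated chain carbon: the change from 2,3-dihydroxyphenyl to 2,5-dihydroxyphenyl gives a 2.4-fold lower number from compound 3 to compound 4 (0.39 log units; beyond the scatter), so the arrangement of the hydroxyl groups matters here, and not merely their presence. Replacing 1H-pyrrol-2-yl with 2,5-dihydroxyphenyl gives a 2.6-fold lower number from compound 1 to compound 4 (0.41 log units; beyond the scatter), the first change from compound 1 to give a lower number beyond the scatter, since the 2,3-dihydroxyphenyl group had stayed level with 1H-pyrrol-2-yl. Measured against the unsubstituted phenyl, the step is a 20-fold lower number from compound 2 to compound 4 (1.31 log units; beyond the scatter), the largest among these compounds, and it makes compound 4 the most potent of the four in this cytotoxicity read-out.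

No supporting measurement is available to explain why 2,5-dihydroxyphenyl outperforms the other groups at this place. The compounds shown leave open whether both free hydroxyl groups are required, as a 2,5-dimethoxyphenyl group or a 3-hydroxyphenyl group would test, and whether an aminophenyl group or a longer chain carrying the 2,5-dihydroxyphenyl ring would keep the lower number.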